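Trimming the Amide Ring: Compound 3 in Rat

The source may report more compounds than this note shows. Statements on the series, on what has been measured and on what is new or still open speak of the compounds shown alone.

compound 1 `CCn1c(-c2cnc(C)nc2)nc2c(N[C@H]3CCN(C(=O)C4CC(F)(F)C4)C3)ncnc21`: 0.9 L/kg
compound 2 `CCn1c(-c2ccc(C(F)(F)F)nc2)nc2c(O[C@H]3CCN(C(=O)C4CC4)C3)ncnc21`: 0.7 L/kg

In an ADME assay (Rattus norvegicus, strain Wistar Han) for pharmacokinetics (a higher number here means that more of the compound sits outside the plasma, a lower number that more of the compound stays in the plasma), compound 1 gives 0.9 L/kg and stands at the top of the two numbers shown, though compound 2 gives 0.7 L/kg and the gap lies within the scatter, so nothing separates the two. Compound 3 `CCn1c(-c2cnc(C)nc2)nc2c(N[C@H]3CCN(C(=O)C4CC4)C3)ncnc21` is compound 1 with one change: cyclopropyl in place of 3,3-difluorocyclobutyl on a carbonyl carbon. Within the data shown here, no measured pair shows this change on its own; compound 2, which also carries cyclopropyl on a carbonyl carbon, sits within the scatter of compound 1. A step of a 1.1-fold lower number from compound 1 to compound 3 (0.05 log units; within the scatter) within the scatter is therefore expected. Compound 3 is estimated at 0.8 L/kg, between 0.5 L/kg and 1.4 L/kg.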

Compound 3, volume of distribution: 1 L/kg
For compound 3 the middle estimate is 1.3-fold (0.10 log units) below the measured one; measured number inside the range.
By their numbers in this assay, from the lowest: compounds 2, 1 and 3 (each within the scatter of the next).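

Among these compounds, exchanging the 3,3-difluorocyclobutyl group on the carbonyl for cyclopropyl gives a 1.1-fold higher number from compound 1 to compound 3 (0.05 log units; within the scatter) in this assay, the first direct reading of this change. With everything else in compound 1 held constant, the two rings cannot be told apart by this measure, and the fluorines can leave this position without a change beyond the scatter. No measurement here explains why the two groups read alike. Still open, on these data alone, is whether a group of a different kind on this carbonyl, such as an amine or a carboxylic acid, would move the number beyond the scatter.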